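The source may report more compounds than this note shows. Statements on the series, on what has been measured and on what is new or still open speak of the compounds shown alone.

Compound 2, drawn as `CN(C(=O)NC(=O)c1c(F)cccc1F)c1nc(C(F)(F)F)c(C(=O)N/N=C/c2cccc(C(F)(F)F)c2)s1`, and compound 1, drawn as `CN(C(=O)NC(=O)c1ccc(Cl)cc1Cl)c1nc(C(F)(F)F)c(C(=O)N/N=C/c2ccc(C(F)(F)F)cc2)s1`, were both tested in a functional assay on A549 cells (Homo sapiens) for inhibition, read by MTT assay, with a stated time of 72 h; on this read-out lower numbers stand for stronger inhibition and higher numbers for weaker inhibition. In this assay compound 1 gives 9.4 ug/mL. In this assay compound 2 gives 27.6 ug/mL, the higher of the two numbers, and the gap between compound 2 and compound 1 lies beyond the usual scatter of repeated measurements. The two structures differ in more than one place, so no single change can be tied to that gap.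

Compound 3, drawn as `CN(C(=O)NC(=O)c1c(F)cccc1F)c1nc(C(F)(F)F)c(C(=O)N/N=C/c2ccc(C(F)(F)F)cc2)s1`, has not yet been measured. It differs from compound 2 in one place: 4-(trifluoromethyl)phenyl in place of 3-(trifluoromethyl)phenyl on a carbon with a double bond to nitrogen, so that compound 3 carries the same group on the carbon with a double bond to nitrogen as compound 1 does, while keeping the rest of compound 2 unchanged. Among the compounds with values here, with no measured pair that isolates this change, the step from compound 2 to compound 3 is expected to be modest and towards a lower number, and the estimated step of a 1.5-fold lower number from compound 2 to compound 3 (0.19 log units; within the scatter) reflects this, because compound 1 gives 9.4 ug/mL. For compound 3 in this assay the expected value is 18 ug/mL, with a range from 8 ug/mL to 40 ug/mL.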

Compound 3, half-maximal inhibitory concentration: 40.1 ug/mL
Estimate against measurement, compound 3: 2.2-fold (0.35 log units) below; the measured number lies above the stated range.
By their numbers in this assay, from the lowest: compound 1; then compounds 2 and 3 (each within the scatter of the next).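

In this assay, 4-(trifluoromethyl)phenyl in place of 3-(trifluoromethyl)phenyl on a carbon with a double bond to nitrogen gives a 1.5-fold higher number from compound 2 to compound 3 (0.16 log units; within the scatter) and so does not separate the two compounds when 2,6-difluorophenyl sits on the carbonyl carbon. At this position, the choice between these two isomeric groups therefore makes no readable difference in this pair. Within the data shown here, the other single change, 2,6-difluorophenyl in place of 2,4-dichlorophenyl on a carbonyl carbon, gives a 4.3-fold higher number from compound 1 to compound 3 (0.63 log units; beyond the scatter) in this assay and is the first change here that can be tied to a gap beyond the scatter, which the comparison of compound 1 with compound 2 could not do; no measured data here explain that gap.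

On these data alone, each change rests on a single pair, so it remains open whether 2,4-dichlorophenyl on the carbonyl carbon would make the same difference alongside 3-(trifluoromethyl)phenyl. The compounds shown also leave open how an unsubstituted phenyl, a pyridine ring or a 4-methoxyphenyl group would read at either position.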